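The compounds below may be only part of what the source reports. "The series", "measured", "known", "first", "only" and "open" are said of these compounds alone.

Compound 1 `COc1cccc(OC)c1C(=O)Nc1c[nH]nc1C(=O)O` carries a carboxy group on its shared core, and in an ADME assay on MRC5 cells (Homo sapiens) for inhibition, with a stated time of 72 h (a lower number here means that less compound is needed, a higher number that more compound is needed for the effect), compound 1 gives only a limit, > 50000 nM, so its true value is not known. It sits at the limit of > 50000 nM in this assay, at which 1 of the 2 values shown sits. Compound 2 `CO[C@H]1CC[C@H](NC(=O)c2n[nH]cc2NC(=O)c2ccccc2C(F)(F)F)CC1`, built on the same core but with different groups, gives 3300 nM in this assay. Compound 3 `COc1cccc(OC)c1C(=O)Nc1c[nH]nc1C(=O)NCCCN(C)C` is compound 1 with one change: (3-(dimethylamino)propyl)amino in place of hydroxy on a carbonyl carbon. For the measured compounds named here, no measured step of this kind exists here, so the expectation rests on compound 1 alone. Compound 3 is expected to move by an at least 2.5-fold lower number from compound 1 to compound 3 (0.39 log units; beyond the scatter) toward lower numbers, within the scatter of the limit or somewhat beyond it. Compound 3 is thus estimated at 20000 nM, in a range from 4000 nM to 50000 nM.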

Compound 3, half-maximal effective concentration: > 50000 nM
Compound 3 was reported as a limit; the forecaster's own chance of this, stated with the estimate: 40%; at least 2.5-fold (0.39 log units) between middle value and limit.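

No step from compound 1 to compound 3 can be read in this assay, since both results are limits and not numbers: the limit of > 50000 nM in this assay, at which 2 of the 3 values shown sit.

Still open, on these data alone, is whether (3-(dimethylamino)propyl)amino in place of hydroxy changes the true value at all, and in which direction.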